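The compounds below may be only part of what the source reports. "The series", "measured", "known", "first", "only" and "open" are said of these compounds alone.

- Compound 1 `O=C1O[C@H]([C@@H](O)Cn2cc(-c3ccc(Br)cc3)nn2)C(OCc2ccccc2)=C1OCc1ccccc1`: 5070 nM
- Compound 2 `O=C1O/C(=C\Cn2cc(-c3cc(F)cc(F)c3)nn2)C(OCc2ccccc2)=C1OCc1ccccc1`: > 100000 nM
- Compound 3 `COc1ccc(-c2cn(C/C=C3\OC(=O)C(OCc4ccccc4)=C3OCc3ccccc3)nn2)cc1`: > 100000 nM

Among the compounds with values here, in a functional assay on HepG2 cells (Homo sapiens) for antiproliferative activity, read by MTT assay, with a stated time of 72 h (on this read-out lower numbers stand for stronger inhibition and higher numbers for weaker inhibition), compound 1 gives 5070 nM, the only true number among the three compounds. For compound 2, > 100000 nM is a limit of the assay and not a number. For compound 3, > 100000 nM is likewise a limit. The upper edge of these readings is the limit of > 100000 nM in this assay, at which 2 of the 3 values shown sit.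

Compound 4 `CC(C)(C)c1cn(C[C@H](O)[C@H]2OC(=O)C(OCc3ccccc3)=C2OCc2ccccc2)nn1` departs from compound 1 at one place, with tert-butyl in place of 4-bromophenyl on an aromatic carbon. Within the data shown here, the only measured step that bears on this change is a step that the two limits leave unreadable from compound 2 to compound 3, also a swap on an aromatic carbon, so it offers no size to carry over. The direction therefore remains an expectation with little support. With compound 1 at 5070 nM there is room on the weak side, and the change removes a ring, so weaker inhibition is tentatively expected. The estimated change is a 3.0-fold higher number from compound 1 to compound 4 (0.47 log units; beyond the scatter). For compound 4 the expected value is 15000 nM, with an estimated range of 3000 nM to 70000 nM.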

Compound 4, half-maximal inhibitory concentration: 29200 nM
For compound 4 the middle estimate is 1.9-fold (0.29 log units) below the measured one; the measured number falls inside the stated range.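

In this assay, within the data shown here, replacing 4-bromophenyl with tert-butyl on this aromatic carbon of the five-membered aromatic ring with 3 nitrogen gives the first step that can be read at this position, a 5.8-fold higher number from compound 1 to compound 4 (0.76 log units; beyond the scatter). The group on this carbon therefore matters to the read-out, yet compound 4 still gives a true number, 29200 nM, with no ring in that group, so a measurable value here does not depend on the six-membered aromatic ring. Compound 2 and compound 3 remain at a limit of the assay and not a number, so the step between them cannot be read: the limit of > 100000 nM in this assay, at which 2 of the 4 values shown sit.

The compounds shown do not separate the contribution of the bromine from that of the ring it sits on, since 4-bromophenyl and tert-butyl differ in both. A plain phenyl, a cyclohexyl group or an amine on this carbon would bear on that question, and none of these is among the compounds shown.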